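The source may report more compounds than this note shows. Statements on the series, on what has been measured and on what is new or still open speak of the compounds shown alone.

Measured so far:
compound 1, `N#Cc1cn(C2OC(CO)CC2O)c2ncnc(N)c12`: 4000 nM
compound 2, `N#Cc1cn(C2C=CC(CO)O2)c2ncnc(N)c12`: 176000 nM

In a functional assay on KB cells (Homo sapiens) for inhibition (on this read-out higher numbers stand for weaker inhibition and lower numbers for stronger inhibition), compound 1 gives 4000 nM, the lower of the two numbers; compound 2 gives 176000 nM, a gap beyond the scatter. Compound 3, `N#Cc1cn(C2CCC(CO)O2)c2ncnc(N)c12`, is not yet measured. It differs from compound 1 by hydrogen in place of hydroxy on a saturated ring carbon. Within the data shown here, no pair of measured compounds isolates this change. Compound 2 also lacks the hydroxy and shows the weakest inhibition here, so for compound 3 a step toward weaker inhibition is expected, a 10-fold higher number from compound 1 to compound 3 (1.00 log units; beyond the scatter). Compound 3 is estimated at 40000 nM, within 8000 nM to 200000 nM.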

Compound 3, half-maximal inhibitory concentration: 88000 nM
Estimate against measurement, compound 3: 2.2-fold (0.34 log units) below; the measured number falls inside the stated range.
By their numbers in this assay, from the lowest: compound 1; then compounds 3 and 2 (each within the scatter of the next).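

In this assay the change to hydrogen on this saturated ring carbon gives a 22-fold higher number from compound 1 to compound 3 (1.34 log units; beyond the scatter) as a large step beyond the scatter. Among these compounds, this is the first read of the hydroxy alone, since compound 2 differs from compound 1 in more than one place, and here stronger inhibition goes with the hydroxy of compound 1. Nothing available accounts for the size of this step.

Only hydroxy and hydrogen are shown on this ring carbon. Going by these compounds, an amine, a fluorine atom or a methoxy group there remains open, as does whether another group could match or exceed compound 1.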